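The source may report more compounds than this note shows. Statements on the series, on what has been measured and on what is new or still open speak of the compounds shown alone.

Measured compounds in an ADME assay on Huh-7 cells (Homo sapiens) for cytotoxicity; on this read-out lower numbers stand for higher toxicity in this test and higher numbers for lower toxicity in this test:
Compound 1 `N#Cc1ccc(C(=O)NC(=S)N2CCc3c(OCCCCCOc4ccc(Cl)cc4)cccc32)cc1` sits at the assay limit, > 50000 nM.
Compound 2 `O=C(NC(=S)N1CCc2c(OCCCCCOc3ccc(Cl)cc3)cccc21)c1ccc(Cl)cc1` gives 21700 nM.
Compound 3 `CCCC(=O)NC(=S)N1CCc2c(OCCCCCOc3ccc(Cl)cc3)cccc21` sits at the assay limit, > 50000 nM.

Compound 3 thus stands at the top of the shown range, together with compound 1 (the limit of > 50000 nM in this assay, at which 2 of the 3 values shown sit). The step to compound 4 `O=C(NC(=S)N1CCc2c(OCCCCCOc3ccc(Cl)cc3)cccc21)c1ccoc1` is furan-3-yl in place of propyl on a carbonyl carbon. The nearest measured steps are an at least 2.3-fold higher number from compound 2 to compound 3 (0.36 log units; beyond the scatter) and a step that the two limits leave unreadable from compound 1 to compound 3; between the two aryl amides, an at least 2.3-fold lower number from compound 1 to compound 2 (0.36 log units; beyond the scatter). Compound 4 carries an aromatic ring like compounds 1 and 2, but no chloro or cyano on it, so the expected step of an at least 1.1-fold lower number from compound 3 to compound 4 (0.04 log units; that floor lies within the scatter) in this assay is none beyond the scatter or a modest lowering. Compound 4 is estimated at 45000 nM, range 20000 nM to 100000 nM.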

Compound 4, half-maximal cytotoxic concentration: 20100 nM
Compound 4: the middle estimate sits 2.2-fold (0.35 log units) above what was measured, within the range that was stated.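

In this assay, a chloro substituent is not needed for the lower number on this carbonyl carbon: furan-3-yl in place of propyl gives an at least 2.4-fold lower number from compound 3 to compound 4 (0.39 log units; beyond the scatter). Furan-3-yl and 4-chlorophenyl cannot be told apart here, with a 1.1-fold lower number from compound 2 to compound 4 (0.03 log units; within the scatter). A ring alone does not set the outcome, since compound 1 goes against that pattern, with an at least 2.4-fold lower number from compound 1 to compound 4 (0.39 log units; beyond the scatter).

As far as these compounds go, how far compound 1 and compound 3 lie past their values stays unread, as both are limits: the limit of > 50000 nM in this assay, at which 2 of the 4 values shown sit. Whether an amine on the furan-3-yl ring or a longer chain in place of propyl would shift this assay remains open.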